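Bromo replacing the dimethylpyrrolyl group on a chromene scaffold

The source may report more compounds than this note shows. Statements on the series, on what has been measured and on what is new or still open speak of the compounds shown alone.

The series rests on a shared core carrying a substituent on the carbocyclic ring. Compound 1 `COc1ccc2c(c1)C(n1ccccc1=O)=CC(C)(C)O2` is the methoxy member, compound 2 `CC1(C)C=C(n2ccccc2=O)c2cc(C(=O)c3ccccc3)ccc2O1` the benzoyl member and compound 3 `Cc1ccc(C)n1-c1ccc2c(c1)C(n1ccccc1=O)=CC(C)(C)O2` the dimethylpyrrolyl member. In a functional assay (trachea) with Rattus norvegicus as the target (on this read-out lower numbers stand for lower potency and higher numbers for higher potency (the scale is a negative logarithm)), compound 1 gives 5.99, compound 2 gives 6.21 and compound 3 gives 6.78, the highest of the three. For the measured compounds named here, two steps bear on the new compound: a number 0.79 log units higher from compound 1 to compound 3 (beyond the scatter) and a number 0.57 log units higher from compound 2 to compound 3 (beyond the scatter), both reached by bringing the dimethylpyrrolyl group in. Compound 4 `CC1(C)C=C(n2ccccc2=O)c2cc(Br)ccc2O1` now takes it away: bromo in place of 2,5-dimethyl-1H-pyrrol-1-yl on an aromatic carbon. A fall of similar size is therefore expected in this assay, meaning a number 0.68 log units lower from compound 3 to compound 4 (beyond the scatter). For compound 4 the estimate is 6.1, ranging from 5.6 to 6.6.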

Compound 4, logarithm of the reciprocal of the active concentration, log(1/C): 7.53
Compound 4: middle estimate off by 1.43 log units, on the low side, outside the stated range (above it).
By their numbers in this assay, from the lowest: compounds 1 and 2 (each within the scatter of the next); then compound 3; then compound 4.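

In this assay, bromo at this aromatic carbon gives the highest number of the four compounds (a number 0.75 log units higher from compound 3 to compound 4 (beyond the scatter)), and the gain is larger against benzoyl (a number 1.32 log units higher from compound 2 to compound 4 (beyond the scatter)) and methoxy (a number 1.54 log units higher from compound 1 to compound 4 (beyond the scatter)). The earlier rise with 2,5-dimethyl-1H-pyrrol-1-yl therefore did not show that a ring is needed here, although methoxy, which also has no ring, gives the lowest number. Nothing available explains this order.

The compounds shown leave open whether chloro, iodo, or a nitrile would match bromo at this carbon. They also leave open whether bromo would have the same effect on another aromatic carbon of the shared core.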